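The compounds below may be only part of what the source reports. "The series", "measured", "known", "first", "only" and "open" are said of these compounds alone.

Measured so far:
Compound 1 `CC(=O)Nc1ccc(S(=O)(=O)Nc2cccc(-c3nc(-c4ccc(NC(=O)c5cccnc5)cc4C(F)(F)F)no3)c2)cc1` – > 10000 nM
Compound 2 `COc1cc(NC(=O)c2cccnc2)ccc1-c1noc(-c2cccc(NS(=O)(=O)c3ccc(NC(C)=O)cc3)c2)n1` – > 10000 nM
Compound 3 `O=C(Nc1cccc(-c2nc(-c3ccc(NC(=O)c4cccnc4)cc3Cl)no2)c1)Nc1cccc(C(F)(F)F)c1` – 1900 nM

In a functional assay on MDA-MB-231 cells (Homo sapiens) for antiproliferative activity, read by MTT assay, with a stated time of 72 h (a lower number here means a stronger inhibitor, a higher number a weaker inhibitor), compound 1 gives only a limit, > 10000 nM. Compound 2 likewise gives only a limit in this assay, > 10000 nM. The change between them is methoxy in place of trifluoromethyl on an aromatic carbon, and its step, a step that the two limits leave unreadable from compound 1 to compound 2, cannot be read, since both values sit at the limit of > 10000 nM in this assay, at which 2 of the 3 values shown sit. Compound 3 gives a number in this assay, 1900 nM. The difference between the core of compound 3 and that of compound 1 is not broken down here. Compound 4 `COc1cccc(NC(=O)Nc2cccc(-c3nc(-c4ccc(NC(=O)c5cccnc5)cc4Cl)no3)c2)c1` differs from compound 3 by methoxy in place of trifluoromethyl on an aromatic carbon. This is the same kind of change as from compound 1 to compound 2, but the place differs: there the group sat ortho to a large group and meta to a ((pyridin-3-yl)carbonyl)amino group, here meta to a large group. With no readable earlier step to lean on, only a small step, a 1.6-fold higher number from compound 3 to compound 4 (0.20 log units; within the scatter), is expected, resting on compound 3 and its value 1900 nM. Compound 4 is therefore estimated at 3000 nM.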

Compound 4, half-maximal inhibitory concentration: 6700 nM
For compound 4 the middle estimate is 2.2-fold (0.35 log units) below the measured one; the measured number falls inside the stated range.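

In this assay, replacing trifluoromethyl with methoxy on the 3-(trifluoromethyl)phenyl group of compound 3 gives a readable result: a 3.5-fold higher number from compound 3 to compound 4 (0.55 log units; beyond the scatter). The same swap between compound 1 and compound 2 cannot be read, since both give only a limit: the limit of > 10000 nM in this assay, at which 2 of the 4 values shown sit. The change therefore weakens activity on this one core, but nothing here shows whether that effect carries over to the core of compound 1, where the group also sits at a different place.

Going by these compounds, it remains open how an amine or a carboxylic acid would behave at this place on the ring. A single pair also cannot separate the loss of trifluoromethyl from the gain of methoxy.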